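A few compounds are considered here, and "the series" means these few. Any claim that something is new, unique, unknown or untested is made for them only; others in the source may bear on it.

Measured in an in vitro functional assay on 1321-N1 cells for agonist activity at P2Y purinoceptor 2 (Homo sapiens) (on this read-out lower numbers stand for an effect already at smaller amounts and higher numbers for an effect only at larger amounts of compound), compound 1 `Cn1c(=O)ccn([C@@H]2O[C@H](COP(=O)(O)OP(=O)(O)OP(=O)(O)O)[C@@H](O)[C@H]2O)c1=O` gives 564 nM. Compound 2 `Cc1cc(=O)n([C@@H]2O[C@H](COP(=O)(O)OP(=O)(O)OP(=O)(O)O)[C@@H](O)[C@H]2O)c(=O)[nH]1` gives only a limit of the assay, > 1000 nM. Compound 3 `Cn1c(=O)ccn([C@@H]2O[C@H](COP(=O)(O)OP(=O)(O)O)[C@@H](O)[C@H]2O)c1=O` likewise gives only a limit of the assay, > 1000 nM.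

Compound 4 `Cc1cc(=O)n([C@@H]2O[C@H](COP(=O)(O)OP(=O)(O)O)[C@@H](O)[C@H]2O)c(=O)[nH]1` is not yet measured in this assay. It differs from compound 2 by a hydrogen atom in place of a group of 4 heavy atoms (3 oxygen, 1 phosphorus; no ring), on an oxygen. The same change, (a hydrogen atom in place of a group of 4 heavy atoms (3 oxygen, 1 phosphorus; no ring), on an oxygen), is made from compound 1 to compound 3, where it gives an at least 1.7-fold higher number from compound 1 to compound 3 (0.24 log units; that floor lies within the scatter). The cores of compound 1 and compound 2 differ by a group of 9 heavy atoms (5 carbon, 2 nitrogen, 2 oxygen; one six-membered aromatic ring with 2 hetero atoms) in place of a group of 9 heavy atoms (5 carbon, 2 nitrogen, 2 oxygen; one six-membered aromatic ring with 2 hetero atoms), on a saturated ring carbon, with an at least 1.7-fold higher number from compound 1 to compound 2 (0.24 log units; that floor lies within the scatter) between them. Two of the three values sit at the limit of > 1000 nM in this assay, at which 2 of the 3 values shown sit.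

The step from compound 2 to compound 4 is expected to be a step that the limit leaves unreadable from compound 2 to compound 4. That expectation rests on the step of an at least 1.7-fold higher number from compound 1 to compound 3 (0.24 log units; that floor lies within the scatter) and on compound 2 already sitting at the limit of > 1000 nM in this assay, at which 2 of the 3 values shown sit. Compound 4 is expected at 6000 nM, within 1500 nM to 40000 nM, most likely reported only as a limit.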

Compound 4, half-maximal effective concentration: > 1000 nM
Compound 4: a limit, no number; the forecaster's own chance of this, stated with the estimate: 90%; the middle value lies beyond the limit too.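

Compound 2 and compound 4 both stand only as limits, so no step between them can be read: the limit of > 1000 nM in this assay, at which 3 of the 4 values shown sit.

Still open, as far as these compounds go, is how far a hydrogen atom in place of the group of 4 heavy atoms shifts the value of compound 2.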